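The source may report more compounds than this note shows. Statements on the series, on what has been measured and on what is new or still open speak of the compounds shown alone.

Going by the values given here, compound 3 `CCOc1ccc2c(NCCN(C)C)ccnc2c1` gives 6240 nM in a functional assay on DLD-1 cells (Homo sapiens) for cytotoxicity, read by MTT assay, with a stated time of 48 h (a lower number here means a stronger inhibitor, a higher number a weaker inhibitor), the highest of the three numbers so far. Among the compounds with values here, the nearest is compound 1 `CCCCCCOc1ccc2c(Cl)ccnc2c1` at 2660 nM, which differs from compound 3 in two places and so offers no single-change step. Within the data shown here, compound 2 `C=CCOc1ccc2c(NCCN(C)C)ccnc2c1` gives 1530 nM, and the one single-change step in the set, a 4.1-fold higher number from compound 2 to compound 3 (0.61 log units; beyond the scatter), shows that trimming the chain end from vinyl to methyl raises the number by a modest amount beyond the scatter.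

Compound 4 `CCCCCCOc1ccc2c(NCCN(C)C)ccnc2c1` carries the change (butyl in place of hydrogen on a saturated chain carbon, two bonds along the chain from an oxygen on an aromatic ring), that is, ethoxy to hexyloxy while the amine side chain is kept. Among the measured compounds shown here, no measured pair isolates this lengthening; the closest hint is that compound 1, which also bears the hexyloxy group, stands at 2660 nM against compound 3 at 6240 nM, but those two differ in the chloro as well. Given that the only chain step, a 4.1-fold higher number from compound 2 to compound 3 (0.61 log units; beyond the scatter), was modest, a step of similar size in the other direction is expected. The estimate for compound 4 is therefore a 2.5-fold lower number from compound 3 to compound 4 (0.40 log units; beyond the scatter), landing at 2500 nM with a range of 800 nM to 8000 nM.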

Compound 4, half-maximal inhibitory concentration: 1870 nM
Compound 4: the middle estimate sits 1.3-fold (0.13 log units) above what was measured; low and high end bracket the measured number.
By their numbers in this assay, from the lowest: compounds 2, 4 and 1 (each within the scatter of the next); then compound 3.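

Ethoxy to hexyloxy, with the amine side chain kept, gives in this assay the first direct reading of lengthening at this position, on a saturated chain carbon, two bonds along the chain from an oxygen on an aromatic ring: a 3.3-fold lower number from compound 3 to compound 4 (0.52 log units; beyond the scatter) is a modest step. The hexyloxy chain and the vinyl-ended chain of compound 2 are not separated, since a 1.2-fold higher number from compound 2 to compound 4 (0.09 log units; within the scatter) sits within the scatter, so among the compounds carrying the amine side chain, only the ethoxy chain of compound 3 stands apart. With hexyloxy held constant, (2-(dimethylamino)ethyl)amino in place of chloro on an aromatic carbon also gives no separable change, as a 1.4-fold lower number from compound 1 to compound 4 (0.15 log units; within the scatter) is likewise within the scatter.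

Open, going by these compounds, is whether a longer chain such as octyloxy would continue this direction, or whether a branched chain or a chain ending in a hydroxyl group or an amine would hold the number at this level. No supporting data on hand bear on what lies behind these steps.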